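The source may report more compounds than this note shows. Statements on the series, on what has been measured and on what is new or still open speak of the compounds shown alone.

Measured so far in a functional assay on SW 1116 cells (Homo sapiens) for antiproliferative activity, read by MTT assay, with a stated time of 48 h; on this read-out lower numbers stand for stronger inhibition and higher numbers for weaker inhibition:
- compound 1, `Fc1ccccc1CSc1nnc(-c2cnccn2)o1`: 16800 nM
- compound 2, `Clc1ccccc1CSc1nnc(-c2cnccn2)o1`: 15100 nM
- compound 3, `Fc1ccccc1CSc1nnc(-c2cnccn2)s1`: 6770 nM

Compounds 1 and 2 share a core and differ by one change, (chloro in place of fluoro on an aromatic carbon). Across this pair the step is a 1.1-fold lower number from compound 1 to compound 2 (0.05 log units; within the scatter), so the two values sit within the scatter of each other and nothing is to be read from their order. Compound 3 carries a different core; the difference between the two cores is not broken down here. In this assay compound 3 gives the lowest of the three numbers, and its steps to compound 2 and to compound 1 both lie beyond the scatter.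

Compound 4, `Clc1ccccc1CSc1nnc(-c2cnccn2)s1`, is not yet measured. It stands to compound 3 as compound 2 stands to compound 1: the change is chloro in place of fluoro on an aromatic carbon, the same change at the same place. On the core of compound 3 the expected step is a 1.1-fold lower number from compound 3 to compound 4 (0.04 log units; within the scatter), resting on the near-null step seen from compound 1 to compound 2, a 1.1-fold lower number from compound 1 to compound 2 (0.05 log units; within the scatter), and on the value of compound 3, 6770 nM. For compound 4 the estimate in this assay is 6200 nM, expected to fall between 3000 nM and 12500 nM.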

Compound 4, half-maximal inhibitory concentration: 7530 nM
Estimate against measurement, compound 4: 1.2-fold (0.08 log units) below; low and high end bracket the measured number.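

In this assay, chloro in place of fluoro on an aromatic carbon gives a 1.1-fold higher number from compound 3 to compound 4 (0.05 log units; within the scatter), so on the core of compound 3 this change, like the same change on the core of compound 1, leaves no readable difference. The two steps agree across the two cores: the same change on two cores in this assay, a 1.1-fold lower number (0.05 log units; within the scatter) from compound 1 to compound 2 and a 1.1-fold higher number (0.05 log units; within the scatter) from compound 3 to compound 4, 1.2-fold (0.09 log units) apart, within the scatter of two such steps. This shows only that the near-null result of this one change carries over between these two cores; it does not show that a change with a larger step would carry over in the same way, and two pairs in one cell line set no rule for the series as a whole.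

The compounds shown leave open whether a methoxy group, a nitrile or an amine in place of the halogen, at the same place on the six-membered aromatic ring, would give a step beyond the scatter. Also open, going by these compounds, is whether a longer chain in place of that aromatic ring would move the number on either core.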